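This account rests on a few compounds, and the source may have more. Where it says the series, first, only, none or still open, it means among the compounds named here.

In a functional assay on Jurkat cells (Homo sapiens) for inhibition, read by MTT assay, with a stated time of 72 h (on this read-out higher numbers stand for weaker inhibition and lower numbers for stronger inhibition), compound 1 (`C=C(Br)C(=O)Nc1cccc(/C=C/C(=O)Nc2ccc(F)cc2)c1`) gives 6200 nM and compound 2 (`C=C(Br)C(=O)Nc1cccc(/C=C/C(=O)Nc2ccc(C)cc2)c1`) gives 240 nM while compound 3 (`C=C(Br)C(=O)Nc1cccc(/C=C/C(=O)NCc2ccc(C)cc2)c1`) gives 740 nM as the middle of the three numbers. Compound 4 (`C=C(Br)C(=O)Nc1cccc(/C=C/C(=O)Nc2ccc(OC)cc2)c1`) keeps the shared core and carries 4-methoxyphenyl in place of 4-methylbenzyl on an amide-type nitrogen. Like compound 1 and compound 2, it therefore has a substituted phenyl group on that nitrogen rather than a benzyl group. The nearest guide is a 3.1-fold higher number from compound 2 to compound 3 (0.49 log units; beyond the scatter) for the change from 4-methylphenyl to 4-methylbenzyl, and reversing that change would point to a lower number for compound 4. Two other steps urge caution. The substituent on the phenyl group matters greatly, as a 26-fold lower number from compound 1 to compound 2 (1.41 log units; beyond the scatter) shows for methyl in place of fluoro. Compound 1 also goes against any rule favouring phenyl over benzyl, as an 8.4-fold lower number from compound 1 to compound 3 (0.92 log units; beyond the scatter) makes clear. Among the compounds with values here, no methoxy compound has been measured yet, so the range must stay wide. A modest move to a lower number is therefore expected, estimated as a 2.5-fold lower number from compound 3 to compound 4 (0.39 log units; beyond the scatter) in this assay on this evidence. In this assay the estimate for compound 4 is 300 nM with 90 nM to 1200 nM as the expected range of repeat measurements.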

Compound 4, half-maximal inhibitory concentration: 470 nM
Estimate against measurement, compound 4: 1.6-fold (0.19 log units) below; low and high end bracket the measured number.
By their numbers in this assay, from the lowest: compounds 2, 4 and 3 (each within the scatter of the next, the first and the last beyond it); then compound 1.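

On the aromatic carbon of the phenyl group, methoxy in place of methyl gives a 2.0-fold higher number from compound 2 to compound 4 (0.29 log units; within the scatter) in this assay, while methoxy in place of fluoro gives a 13-fold lower number from compound 1 to compound 4 (1.12 log units; beyond the scatter), so this second substituent shows that the methyl result is not a lone case: among the three groups tested there, fluoro alone stands apart, with compound 1 separated from both compound 2 and compound 4 by more than the scatter. The change from 4-methylbenzyl to 4-methoxyphenyl on the amide-type nitrogen gives a 1.6-fold lower number from compound 3 to compound 4 (0.20 log units; within the scatter), so an aryl group on that nitrogen does not by itself separate compounds here, even though compound 2 and compound 3 do differ beyond the scatter. The material at hand offers nothing that accounts for why fluoro departs from methyl and methoxy.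

As far as these compounds go, it remains open whether a chloro, a hydroxyl or a dimethylamino group on that aromatic carbon would fall with methyl and methoxy or with fluoro. Also unsettled is how 4-methoxybenzyl or a longer chain such as 2-phenylethyl on the amide-type nitrogen would compare with these compounds.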